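The source may report more compounds than this note shows. Statements on the series, on what has been measured and on what is new or still open speak of the compounds shown alone.

Of the compounds shown here, three have been measured in a functional assay on HFL1 cells for antagonist activity at sphingosine 1-phosphate receptor 2 (Homo sapiens), read by ELISA, with a stated time of 24 h, in the absence of a further agent; a higher number here means a weaker inhibitor, a lower number a stronger inhibitor. Compound 1 `Cc1cc(CNC(=O)Nc2cc(Cl)nc(Cl)c2)ncc1-c1cn(C)nc1C` gives 0.77 nM, compound 3 `Cc1cc(CNC(=O)Nc2cc(Cl)cc(Cl)c2)ncc1-c1cn(C)nc1C` gives 0.3 nM, and compound 2 `CCOc1cc(NC(=O)NCc2cc(C)c(-c3cn(C)nc3C)cn2)cc(Cl)n1` gives 0.032 nM, the lowest number of the three and beyond the scatter from both others. The two measured changes both sit at the same end of the molecule, on the group attached to the urea nitrogen: a 24-fold lower number from compound 1 to compound 2 (1.38 log units; beyond the scatter), and a 2.6-fold lower number from compound 1 to compound 3 (0.41 log units; beyond the scatter). Compound 4 `CCOc1cc(NC(=O)NCc2cc(C)c(N3CC(C)OC(C)C3)cn2)cc(Cl)n1` differs from compound 2 at the opposite end: 2,6-dimethylmorpholin-4-yl in place of 1,3-dimethyl-1H-pyrazol-4-yl on an aromatic carbon. Neither measured step touches this part of the structure, so the data give no direct guide to the size or direction of the effect, and the expectation rests only on compound 2 setting the lowest number seen. Swapping an aromatic ring for a non-aromatic one at this position has not been tested here, so a wide range is the honest answer. Compound 4 is expected to give 0.1 nM, estimated between 0.01 nM and 1 nM. The expected step is a 3.1-fold higher number from compound 2 to compound 4 (0.49 log units; beyond the scatter), a modest weakening that could well be absent.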

Compound 4, half-maximal inhibitory concentration: 105 nM
Estimate against measurement, compound 4: 1100-fold (3.02 log units) below, outside the stated range (above it).
By their numbers in this assay, from the lowest: compound 2; then compound 3; then compound 1; then compound 4.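

In this assay, among the compounds shown here, the place on the ring that holds the 1,3-dimethyl-1H-pyrazol-4-yl group proves far more sensitive than the earlier steps at the urea end could show: 2,6-dimethylmorpholin-4-yl there gives a 3300-fold higher number from compound 2 to compound 4 (3.52 log units; beyond the scatter). The two groups match in hydrogen-bond donors, hydrogen-bond acceptors and net charge, and are close in heavy atoms, so those counts do not separate them, while the five-membered aromatic ring and the six-membered non-aromatic ring do differ. No measurement at hand gives a reason for this loss.

With a single replacement at this place, the ring type, the ring size and the methyl groups on the morpholine cannot be told apart. Going by these compounds, whether a phenyl ring or a morpholine ring without its methyl groups would sit nearer compound 2 or nearer compound 4 stays open.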